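Opening notes: a new group on the aromatic amine nitrogen

A few compounds are considered here, and "the series" means these few. Any claim that something is new, unique, unknown or untested is made for them only; others in the source may bear on it.

Measured so far in an assay on CHO cells for inhibition of Amine oxidase [copper-containing] 3 (Homo sapiens), read by spectrophotometry, with stated times of 30 min and 1 h; on this read-out higher numbers stand for weaker inhibition and lower numbers for stronger inhibition:
- compound 1 `CC(=O)Nc1nc(CCc2ccc(N)cc2)cs1`: > 100000 nM
- compound 2 `CC(=O)Nc1nc(CCc2ccc(NC3=NCCN3)cc2)cs1`: 3000 nM

Compound 1 gives only a limit of this assay, > 100000 nM; it sits at the limit of > 100000 nM in this assay, at which 1 of the 2 values shown sits. Compound 2 gives 3000 nM. Going by the values given here, the only measured step is an at least 33-fold lower number from compound 1 to compound 2 (1.52 log units; beyond the scatter).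

Compound 3 `CCNC(=N)Nc1ccc(CCc2csc(NC(C)=O)n2)cc1` differs from compound 1 by a group of 5 heavy atoms (3 carbon, 2 nitrogen; no ring) in place of a hydrogen atom, on a nitrogen on an aromatic ring. Among the compounds with values here, this change and the one from compound 1 to compound 2 both add a group of 5 heavy atoms (3 carbon, 2 nitrogen) at the same nitrogen, so a step in the same direction as an at least 33-fold lower number from compound 1 to compound 2 (1.52 log units; beyond the scatter) is expected, though with compound 1 at a limit its size is uncertain. Compound 3 is expected at 6000 nM, within 1000 nM to 60000 nM. That estimate corresponds to an at least 16-fold lower number from compound 1 to compound 3 (1.22 log units; beyond the scatter).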

Compound 3, half-maximal inhibitory concentration: 680 nM
The estimate for compound 3 lay 8.8-fold (0.95 log units) above the measured number, and the stated range ends above it.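

Placing the open-chain group on the nitrogen on the aromatic ring shows an at least 140-fold lower number from compound 1 to compound 3 (2.16 log units; beyond the scatter) in this assay, so the gain seen with this kind of change does not require the five-membered ring of compound 2. The open-chain group in place of that ring gives a 4.4-fold lower number from compound 2 to compound 3 (0.64 log units; beyond the scatter), so the two groups are distinguishable at this nitrogen. The first step starts from a limit, so its size stays a bound: the limit of > 100000 nM in this assay, at which 1 of the 3 values shown sits.

Open, on these data alone, is how an unsubstituted guanidine or a propyl chain in place of the ethyl group would compare at this nitrogen.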